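The compounds below may be only part of what the source reports. "The series", "measured", "known", "first", "only" and "open" are said of these compounds alone.

Measured so far in an assay on CHO cells for displacement of a labelled ligand from prostaglandin E2 receptor EP3 subtype (Mus musculus), read by scintillation counting, with a stated time of 60 min; on this read-out lower numbers stand for stronger inhibition and higher numbers for weaker inhibition:
Compound 1 `O=C(O)CCCSCCN1C(=O)OC[C@@H]1/C=C/[C@@H](O)Cc1ccccc1` gives 6400 nM.
Compound 2 `O=C(O)CCCSCCN1C(=O)OC[C@@H]1/C=C/[C@@H](O)Cc1cccc(-c2ccccc2)c1` gives only a limit, > 10000 nM.
Compound 3 `CCc1cccc(C[C@H](O)/C=C/[C@H]2COC(=O)N2CCSCCCC(=O)O)c1` gives 2700 nM.

Compound 3 holds the lowest number of the two reported, with compound 1 nearest: a 2.4-fold lower number from compound 1 to compound 3 (0.37 log units; beyond the scatter). Compound 2 sits at the assay limit (the limit of > 10000 nM in this assay, at which 1 of the 3 values shown sits).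

Compound 4 `COCc1cccc(C[C@H](O)/C=C/[C@H]2COC(=O)N2CCSCCCC(=O)O)c1` differs from compound 3 by methoxy in place of methyl on a saturated chain carbon bound to an aromatic carbon. Going by the values given here, no measured step touches this methyl-to-methoxy change; the steps seen all alter the aromatic substituent itself: an at least 1.5-fold higher number from compound 1 to compound 2 (0.19 log units; that floor lies within the scatter), a 2.4-fold lower number from compound 1 to compound 3 (0.37 log units; beyond the scatter) and an at least 3.7-fold lower number from compound 2 to compound 3 (0.56 log units; beyond the scatter). The larger phenyl weakened binding and the small ethyl improved it, so a small change within the same side chain is expected to move this assay little, if at all, beyond the scatter: a 1.3-fold higher number from compound 3 to compound 4 (0.11 log units; within the scatter).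

Compound 4 is therefore estimated at 3500 nM, between 1300 nM and 9500 nM.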

Compound 4, inhibition constant: > 10000 nM
Compound 4: no number, only a limit; the forecaster's own chance of this, stated with the estimate: 10%; middle value at least 2.8-fold (0.45 log units) away from the limit.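

Methoxy in place of methyl on a saturated chain carbon bound to an aromatic carbon gives an at least 3.7-fold higher number from compound 3 to compound 4 (0.56 log units; beyond the scatter), so the gain seen with ethyl does not extend to methoxymethyl. Replacing hydrogen with methoxymethyl on an aromatic carbon gives an at least 1.5-fold higher number from compound 1 to compound 4 (0.19 log units; that floor lies within the scatter), a floor that leaves compound 4 unranked against compound 1. The step between compound 2 and compound 4 cannot be read, as both values are limits: the limit of > 10000 nM in this assay, at which 2 of the 4 values shown sit.

The compounds shown do not separate the oxygen from the longer chain. A propyl group at this place would bear on that question, and a hydroxymethyl group would test whether any oxygen-bearing chain is accepted here.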